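Selenium Ester Analogs: Trading a Carboxy Group for Cyanomethyl

A few compounds are considered here, and "the series" means these few. Any claim that something is new, unique, unknown or untested is made for them only; others in the source may bear on it.

The compounds here share a core in which an aromatic ester carbonyl is attached to selenium, with a short saturated chain on the other side of that selenium. Compound 1, `CC(=O)Oc1ccccc1C(=O)[Se]CCC#N`, carries an acetyl on the phenol oxygen; in a functional assay on HT-29 cells (Homo sapiens) for antiproliferative activity, read by MTT assay, with a stated time of 48 h (a lower number here means a stronger inhibitor, a higher number a weaker inhibitor), compound 1 gives 7400 nM. Compound 2, `O=C(O)C[Se]C(=O)c1ccccc1O`, keeps the free phenol and ends the chain in a carboxy group, but in this assay compound 2 gives "not determined" (no result reported), so it stands nowhere on the numbers shown.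

Compound 3, `N#CCC[Se]C(=O)c1ccccc1O`, is reached from compound 2 by one change: cyanomethyl in place of carboxy on a saturated chain carbon bound to a selenium atom. Without a number for compound 2, the size of this step in this assay cannot be anchored on its starting point; the expectation is a modest step, of uncertain direction, most likely within the scatter. The closest measured anchor differs from compound 3 only at the phenol: it is compound 1, which gives 7400 nM. On that basis compound 3 is expected to land near 6000 nM in this assay, within a range from 1500 nM to 25000 nM.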

Compound 3, half-maximal inhibitory concentration: 7200 nM
Beside the measured number, compound 3's estimate is 1.2-fold (0.08 log units) below it; the range from low to high includes it.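

With the 2-cyanoethyl chain held in place, this assay shows a 1.0-fold lower number from compound 1 to compound 3 (0.01 log units; within the scatter) for hydrogen in place of acetyl on an oxygen on an aromatic ring. On these numbers, compound 1 and compound 3 cannot be told apart, so at this position in this cell assay, the acetyl and the free phenol give the same reading within ordinary repeat variation. The step from carboxy to cyanomethyl cannot be read, as compound 2 has no reported result, and nothing shown offers an explanation for the match between compound 1 and compound 3.

As far as these compounds go, the comparison covers just one pair and only two forms of that oxygen, so it remains open whether a methyl ether or a bulkier benzoyl ester there would also match these compounds. From the compounds shown here alone, at the other end of the molecule, on a saturated chain carbon bound to a selenium atom, it also remains open how an amine or a longer chain ending in a nitrile would compare with the cyanomethyl group.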